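Replacing a Dimethoxyphenyl with a Methoxypyridinyl: an Expected Outcome

The source may report more compounds than this note shows. Statements on the series, on what has been measured and on what is new or still open speak of the compounds shown alone.

Compound 1 `CCS(=O)(=O)Nc1cc(-c2ccc3ncnc(Nc4ccc(OC)c(OC)c4)c3c2)cnc1OC`: 5820 nM
Compound 2 `CCCCS(=O)(=O)Nc1cc(-c2ccc3ncnc(Nc4ccc(F)c(Cl)c4)c3c2)cnc1OC`: 77100 nM

Both values come from a functional assay on A549 cells (Homo sapiens) for cytotoxicity, read by sulforhodamine B assay, with a stated time of 72 h; on this read-out lower numbers stand for stronger inhibition and higher numbers for weaker inhibition. Compound 1 has the lower of the two numbers, so it inhibits more strongly; compound 2 stands well above it, and that gap lies beyond the scatter. The two compounds differ in more than one place, so no single change can be read from them.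

Compound 3 `CCS(=O)(=O)Nc1cc(-c2ccc3ncnc(Nc4ccc(OC)nc4)c3c2)cnc1OC` has not yet been measured. It differs from compound 1 by one change: 6-methoxypyridin-3-yl in place of 3,4-dimethoxyphenyl on a nitrogen on an aromatic ring. Among the measured compounds shown here, no measured pair shows this change on its own. Since the change keeps the same count of hydrogen-bond acceptors and only trades one ring for a closely related one, a modest step in this assay is expected, most likely a slight weakening, and the step from compound 1 to compound 3 is estimated as a 1.5-fold higher number from compound 1 to compound 3 (0.19 log units; within the scatter). Compound 3 is therefore expected to give about 9000 nM, within a range of 3000 nM to 30000 nM.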

Compound 3, half-maximal inhibitory concentration: 5560 nM
Estimate against measurement, compound 3: 1.6-fold (0.21 log units) above; the range from low to high includes it.
By their numbers in this assay, from the lowest: compounds 3 and 1 (each within the scatter of the next); then compound 2.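

In this assay the change on a nitrogen on an aromatic ring gives a 1.0-fold lower number from compound 1 to compound 3 (0.02 log units; within the scatter) and so leaves compound 1 and compound 3 indistinguishable. Among the compounds shown here, this is the first pair that differs in one place, and it shows that, at this position, 6-methoxypyridin-3-yl can stand in for 3,4-dimethoxyphenyl with no measurable difference on this read-out, even though the ring now holds a hetero atom and the group has lost two heavy atoms. No available evidence bears on why the two compounds read alike.

Going by these compounds, whether an amine or a carboxylic acid on this ring in place of the methoxy group would shift the number remains open. Compound 2 differs from compound 1 in more than one place, so its much higher number cannot be assigned to this position.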